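Cyano Substitution on a Pyridine Across Two Bicyclic Amine Cores

A few compounds are considered here, and "the series" means these few. Any claim that something is new, unique, unknown or untested is made for them only; others in the source may bear on it.

The measured compounds are:
compound 1, `c1cncc(N2CC[C@H]3CN[C@H]3C2)c1`, 48 nM;
compound 2, `N#Cc1cncc(N2CC[C@H]3CN[C@H]3C2)c1`, 1000 nM;
compound 3, `c1cncc(N2C[C@@H]3CCNC[C@@H]32)c1`, 1700 nM.

All three were tested in a functional assay on HEK293 cells for agonist activity at Neuronal acetylcholine receptor; alpha3/beta4 (Homo sapiens), read by FLIPR; a lower number here means that less compound is needed, a higher number that more compound is needed for the effect. Compound 1 gives 48 nM and is the compound with the lowest number in this set. Compound 2 carries the change (cyano in place of hydrogen on an aromatic carbon), and this single alteration produced a 21-fold higher number from compound 1 to compound 2 (1.32 log units; beyond the scatter). Compound 3 has the same atoms as compound 1 joined differently; the difference between the two cores is not broken down here. In this assay compound 3 gives 1700 nM, the highest number among the three, although the gap to compound 2 lies within the scatter.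

Compound 4, `N#Cc1cncc(N2C[C@@H]3CCNC[C@@H]32)c1`, has not yet been measured. It differs from compound 3 by cyano in place of hydrogen on an aromatic carbon, and the place line for this change is identical to that of the change from compound 1 to compound 2, so it is the same change applied to the core of compound 3. Within the data shown here, whether the step transfers between the two cores cannot be known from two examples alone, but the only precedent is the large step seen from compound 1 to compound 2. The step from compound 3 to compound 4 is therefore expected to be a 15-fold higher number from compound 3 to compound 4 (1.17 log units; beyond the scatter), because the same change gave a 21-fold higher number from compound 1 to compound 2 (1.32 log units; beyond the scatter). Compound 4 is accordingly estimated at 25000 nM, within a range from 6000 nM to 100000 nM, with a real chance that this assay returns only a limit rather than a number.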

Compound 4, half-maximal effective concentration: 2560 nM
For compound 4 the middle estimate is 9.8-fold (0.99 log units) above the measured one, outside the stated range (below it).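

In this assay, cyano in place of hydrogen on an aromatic carbon of the core of compound 3 gave a 1.5-fold higher number from compound 3 to compound 4 (0.18 log units; within the scatter), a step that stays within the scatter, whereas the same change on the core of compound 1 gave a 21-fold higher number from compound 1 to compound 2 (1.32 log units; beyond the scatter). The size of the step therefore did not carry from one core to the other, and the two steps clearly differ: the same change on two cores in this assay, a 21-fold higher number (1.32 log units; beyond the scatter) from compound 1 to compound 2 and a 1.5-fold higher number (0.18 log units; within the scatter) from compound 3 to compound 4, 14-fold (1.14 log units) apart, beyond the scatter of two such steps. This shows that in this series the outcome of the change cannot be read across from one core to the other, but with a single pair on each core it does not show which feature of the cores separates the two steps, nor what the change would do on a third core.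

The compounds shown hold only hydrogen or cyano at this place on the pyridine, so it remains open whether fluorine, chlorine or a methoxy group there would also give steps that differ between the two cores. Also open, as far as these compounds go, is whether the difference between the two steps would hold at a different position on the ring, since every cyano shown sits two atoms from the ring nitrogen.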